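One chloro removed from a kinase inhibitor

The source may hold more compounds than are shown below. What is called first, only, known or untested is meant among the compounds shown, and "the series" means these compounds.

Within the data shown here, compound 1 `Clc1c[nH]c2ncnc(N3CCc4[nH]cnc4C3)c12` is the only compound here with a numerical result: in an assay on isolated protein for inhibition of RAC-alpha serine/threonine-protein kinase (Homo sapiens) (a lower number here means a stronger inhibitor, a higher number a weaker inhibitor), compound 1 gives 42 nM. Compound 2 `Cc1nnc(-c2ccc(Cl)cc2Nc2ncnc3[nH]ccc23)[nH]1` reaches only a limit of the assay, giving > 10000 nM in this assay. the limit of > 10000 nM in this assay, at which 1 of the 2 values shown sits, marks where that limit sits. Compound 3 `c1nc(N2CCc3[nH]cnc3C2)c2cc[nH]c2n1` differs from compound 1 by hydrogen in place of chloro on an aromatic carbon. Among the measured compounds shown here, with no measured pair of this kind to lean on, the change is expected to weaken inhibition by an amount beyond the usual scatter, a 6.0-fold higher number from compound 1 to compound 3 (0.77 log units; beyond the scatter). Compound 3 is therefore estimated at 250 nM, with a range from 60 nM to 1000 nM.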

Compound 3, half-maximal inhibitory concentration: 294 nM
Beside the measured number, compound 3's estimate is 1.2-fold (0.07 log units) below it; measured number inside the range.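

Among these compounds, this is the first measured pair at this position. In this assay, hydrogen in place of chloro on this aromatic carbon gives a 7.0-fold higher number from compound 1 to compound 3 (0.85 log units; beyond the scatter), so the position responds to the change, although compound 3 still gives a numerical result of 294 nM. Nothing shown offers a reason for this step.

Only chloro and hydrogen can be compared at this carbon. Going by these compounds, whether fluoro, bromo, methyl or a nitrile there would match chloro, or fall nearer to hydrogen, remains open.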